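The source may report more compounds than this note shows. Statements on the series, on what has been measured and on what is new or still open speak of the compounds shown alone.

Among the measured compounds shown here, in a functional assay on LNCaP cells (Homo sapiens) for cytotoxicity, read by MTT assay, with a stated time of 72 h (a lower number here means a stronger inhibitor, a higher number a weaker inhibitor), compound 2 `CC1=C(/C=C/C(=O)/C=C/c2cc(C(F)(F)F)cc(C(F)(F)F)c2)C(C)(C)CCC1` gives 8700 nM, the highest of the two numbers measured so far, while compound 1 `CC1=C(/C=C/C(=O)/C=C/c2cccc(C(F)(F)F)c2)C(C)(C)CCC1` gives 2800 nM. Compound 3 `CC1=C(/C=C/C(=O)/C=C/c2cc(C(F)(F)F)cc(C(F)(F)F)c2)C(C)(C)CCC1O` is compound 2 with one change: hydroxy in place of hydrogen on a saturated ring carbon. A hydroxy group takes the place of hydrogen on a saturated ring carbon, and compound 3 has not yet been measured. For the measured compounds named here, only one measured step is available, a 3.1-fold higher number from compound 1 to compound 2 (0.49 log units; beyond the scatter), a modest one in which trifluoromethyl replaces hydrogen on an aromatic carbon. That step lies elsewhere in the molecule and involves a different group, so it gives no direct measure of the new change. No size or direction can be firmly argued from it, and no step beyond the scatter is expected in this assay. The expected result is a 1.2-fold lower number from compound 2 to compound 3 (0.09 log units; within the scatter). For compound 3 the estimated value is 7000 nM, with an expected range from 2500 nM to 20000 nM.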

Compound 3, half-maximal inhibitory concentration: 2100 nM
Beside the measured number, compound 3's estimate is 3.3-fold (0.52 log units) above it; measured number below the stated range.
By their numbers in this assay, from the lowest: compounds 3 and 1 (each within the scatter of the next); then compound 2.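

In this assay, among the compounds shown here, the saturated ring carbon proves to be a place that matters: hydroxy in place of hydrogen there gives a 4.1-fold lower number from compound 2 to compound 3 (0.62 log units; beyond the scatter) and so shows that the end of the molecule now named 3-hydroxy-2,6,6-trimethylcyclohex-1-en-1-yl bears on the read-out, which the earlier compounds, identical at that end, could not show. This step runs opposite in direction to a 3.1-fold higher number from compound 1 to compound 2 (0.49 log units; beyond the scatter) that came with trifluoromethyl on an aromatic carbon, so the number is not set by the aromatic substitution alone. Nothing available explains the size or direction of the hydroxy step.

For the compounds shown here, whether hydroxy would give a similar step on compound 1, with its single trifluoromethyl, stays open, as only one pair of compounds carries this change. Also open, from the compounds shown here alone, is how a methoxy, an amine or a carbonyl on the same ring carbon would compare with hydroxy.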